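Changing the amide end group of compound 2

The source may hold more compounds than are shown below. What is called first, only, known or untested is meant among the compounds shown, and "the series" means these compounds.

In an ADME assay on L02 cells (Homo sapiens) for cytotoxicity, read by MTT assay, with a stated time of 72 h (on this read-out higher numbers stand for weaker inhibition and lower numbers for stronger inhibition), compound 1 `C=C(F)C(=O)Nc1cccc(Oc2nc(Nc3ccn(C)n3)nc3c2CSCC3)c1` gives 47800 nM. Compound 2 `COc1cccc(Nc2nc3c(c(Oc4cccc(NC(=O)/C=C/C(C)C)c4)n2)CSCC3)c1` reads > 50000 nM, which is a limit of the assay and not a number. Compound 3 `C=C(F)C(=O)Nc1cccc(Oc2nc(Nc3cccc(OC)c3)nc3c2CSCC3)c1` differs from compound 2 by 1-fluoroethenyl in place of 3-methylbut-1-en-1-yl on a carbonyl carbon. The entering group also occurs in compound 1, which gives 47800 nM, so only a modest shift towards stronger inhibition is expected. The expected change is an at least 1.4-fold lower number from compound 2 to compound 3 (0.15 log units; that floor lies within the scatter), a small step towards lower numbers. The estimate for compound 3 is 35000 nM, with an expected range of 12000 nM to 60000 nM.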

Compound 3, half-maximal inhibitory concentration: 41200 nM
Compound 3: the middle estimate sits 1.2-fold (0.07 log units) below what was measured; the range from low to high includes it.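

In this assay, 1-fluoroethenyl in place of 3-methylbut-1-en-1-yl on a carbonyl carbon gives an at least 1.2-fold lower number from compound 2 to compound 3 (0.08 log units; that floor lies within the scatter), and this figure is only a floor, because one end of the step is a limit of the assay: the limit of > 50000 nM in this assay, at which 1 of the 3 values shown sits. With 1-fluoroethenyl kept, 3-methoxyphenyl in place of 1-methyl-1H-pyrazol-3-yl on a nitrogen on an aromatic ring gives a 1.2-fold lower number from compound 1 to compound 3 (0.06 log units; within the scatter), so the two compounds carrying this end group read alike.

As far as these compounds go, it stays open how an unsubstituted ethenyl group or a chain ending in a dimethylamino group would read on this carbonyl carbon. From the compounds shown here alone, the true size of the step from the limit also stays open.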